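Chain extension in a cyanoguanidine cytotoxicity series

This account rests on a few compounds, and the source may have more. Where it says the series, first, only, none or still open, it means among the compounds named here.

Measured so far:
- compound 1 `CC1C(=O)N(CCCCCCCOc2ccc(Cl)cc2)/C(=N\C#N)N1c1ccncc1`: 370 nM
- compound 2 `N#C/N=C1\N(CCCCCOc2ccc(Cl)cc2)C(=O)C(c2ccccc2)N1c1ccncc1`: 337 nM
- compound 3 `N#C/N=C1\N(CCCCCOc2ccc(Cl)cc2)C(=O)CCN1c1ccncc1`: 6740 nM

All three were tested in a functional assay on DLD-1 cells (Homo sapiens) for cytotoxicity; a lower number here means a stronger inhibitor, a higher number a weaker inhibitor. Compound 3 stands with the highest number of the three: compound 1 and compound 2 both lie far below it, and both of those gaps are beyond the scatter. Compound 1 and compound 2 themselves lie within the scatter of each other, so no order is drawn between them.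

Compound 4 `N#C/N=C1\N(CCCCCCCOc2ccc(Cl)cc2)C(=O)CCN1c1ccncc1` is not yet measured. It differs from compound 3 in one place: 2-(4-chlorophenoxy)ethyl in place of 4-chlorophenoxy on a saturated chain carbon, five bonds along the chain from an amide-type nitrogen in a ring. Going by the values given here, no pair of measured compounds isolates this change, since compound 1 carries the longer chain together with a further substituent on the core, so the two values of compound 1 and compound 3 show only their combined difference.

The chain of compound 4 matches that of compound 1, and compound 1 gives 370 nM, so a lower number than compound 3 is expected for compound 4, though with wide uncertainty. The expected step is a 4.5-fold lower number from compound 3 to compound 4 (0.65 log units; beyond the scatter). Compound 4 is estimated at 1500 nM, within 400 nM to 6000 nM.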

Compound 4, half-maximal inhibitory concentration: 3200 nM
Compound 4: the middle estimate sits 2.1-fold (0.33 log units) below what was measured; low and high end bracket the measured number.
By their numbers in this assay, from the lowest: compounds 2 and 1 (each within the scatter of the next); then compound 4; then compound 3.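

In this assay, going by these compounds alone, 2-(4-chlorophenoxy)ethyl in place of 4-chlorophenoxy on a saturated chain carbon, five bonds along the chain from an amide-type nitrogen in a ring, gives the first isolated reading of this change: a 2.1-fold lower number from compound 3 to compound 4 (0.32 log units; beyond the scatter) is a modest step, though beyond the scatter. The longer chain alone therefore accounts for only part of the earlier separation, as compound 4 at 3200 nM keeps a higher number than compound 1 at 370 nM with its further core substituent. No measurement at hand explains the step.

Still open, from the compounds shown here alone, is whether a chain longer than that of compound 4 lowers the number further or reverses the step. Also open, going by these compounds, is whether an amine in place of the chain oxygen keeps the step.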